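This account rests on a few compounds, and the source may have more. Where it says the series, first, only, none or still open, it means among the compounds named here.

For the measured compounds named here, in a functional assay on MCF7 cells (Homo sapiens) for cytotoxicity, read by MTT assay, with a stated time of 96 h (a lower number here means a stronger inhibitor, a higher number a weaker inhibitor), compound 1 (`COc1cc(C(=O)c2cn(-c3ccccc3)cc2-c2ccccc2Cl)cc(OC)c1OC`) gives 76 nM, the lower of the two numbers so far, and compound 2 (`COc1cc(C(=O)c2cn(-c3ccccc3)cc2-c2cc(F)ccc2F)cc(OC)c1OC`) gives 230 nM. Compound 3 (`COc1cc(C(=O)c2cn(-c3ccc(C)cc3)cc2-c2ccccc2Cl)cc(OC)c1OC`) departs from compound 1 by methyl in place of hydrogen on an aromatic carbon, which is phenyl to 4-methylphenyl. Going by the values given here, the only measured step, a 3.0-fold higher number from compound 1 to compound 2 (0.48 log units; beyond the scatter), is modest but lies beyond the scatter. Among the compounds with values here, it concerns a different place in the molecule, so no measured step speaks directly to this change. A step beyond the scatter in this assay is therefore not expected, and no direction is favoured. The estimated step is a 1.2-fold higher number from compound 1 to compound 3 (0.07 log units; within the scatter). Compound 3 is expected at 90 nM, with an estimated range of 30 nM to 270 nM.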

Compound 3, half-maximal inhibitory concentration: 180 nM
For compound 3 the middle estimate is 2.0-fold (0.30 log units) below the measured one, within the range that was stated.
By their numbers in this assay, from the lowest: compound 1; then compounds 3 and 2 (each within the scatter of the next).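

Phenyl to 4-methylphenyl gives a 2.4-fold higher number from compound 1 to compound 3 (0.37 log units; beyond the scatter) in this assay, the first measured change at this position, para to a large group. The position therefore responds to substitution: a single methyl in place of hydrogen moves the number upward, modestly but beyond the scatter. No measurement available here accounts for this step. Going by these compounds, whether a methoxy group, a chlorine atom or an amine in the same place would move the number in the same direction remains open. So does whether methyl has a similar effect alongside the 2,5-difluorophenyl group of compound 2.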